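Swapping a Carbamoyl for Acetamidomethyl in a Hydrolase Inhibitor

A few compounds are considered here, and "the series" means these few. Any claim that something is new, unique, unknown or untested is made for them only; others in the source may bear on it.

Among the measured compounds shown here, compound 1 `Cn1nc2c(=O)n(CC3(O)CCN(Cc4ccc(-c5ccco5)cc4Cl)CC3)cnc2c1-c1ccc(C(N)=O)cc1` was tested in an assay on isolated protein for inhibition of ubiquitin carboxyl-terminal hydrolase 7 (Homo sapiens), with stated times of 30 min and 2 h (a higher number here means a weaker inhibitor, a lower number a stronger inhibitor), and gives 80.8 nM, the lower of the two numbers measured so far. Compound 2 `Cn1nc2c(=O)n(CC3(O)CCN(Cc4ccc(-c5ccoc5)cc4Cl)CC3)cnc2c1-c1ccc(CN)cc1` gives 177 nM in this assay, a difference beyond the usual scatter; these two compounds differ in more than one place, so no single step can be read from them. Compound 3 `CC(=O)NCc1ccc(-c2c3ncn(CC4(O)CCN(Cc5ccc(-c6ccco6)cc5Cl)CC4)c(=O)c3nn2C)cc1` is compound 1 with one change: acetamidomethyl in place of carbamoyl on an aromatic carbon. For the measured compounds named here, no measured pair shows this change on its own. The step of a 1.9-fold higher number from compound 1 to compound 3 (0.27 log units; within the scatter) is expected to be modest, toward a weaker inhibitor. Compound 3 is estimated at 150 nM, with a range from 50 nM to 450 nM.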

Compound 3, half-maximal inhibitory concentration: 46.1 nM
The estimate for compound 3 lay 3.3-fold (0.51 log units) above the measured number, and the stated range ends above it.
By their numbers in this assay, from the lowest: compounds 3 and 1 (each within the scatter of the next); then compound 2.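

In this assay acetamidomethyl in place of carbamoyl gives a 1.8-fold lower number from compound 1 to compound 3 (0.24 log units; within the scatter) and so this position, para to a large group, takes the larger acetamidomethyl group with no change beyond the scatter. Among the compounds shown here, the two groups cannot be told apart by this result, which is the first reading of a single change at this place. No measured evidence on why this is so is at hand.

On these data alone, whether a carboxylic acid or a longer chain ending in an amide would fare the same at this position stays open.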